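The source may report more compounds than this note shows. Statements on the series, on what has been measured and on what is new or still open speak of the compounds shown alone.

Compound 1 `CCCCOC(=O)CCC(=O)N1CCN(CCCOc2cc3c(Nc4ccc(F)c(Cl)c4)ncnc3cc2OC)CC1` and compound 2 `CCCCCCCCCOC(=O)CCC(=O)N1CCN(CCCOc2cc3c(Nc4ccc(F)c(Cl)c4)ncnc3cc2OC)CC1` share the same core and differ only in the length of the ester chain. In a functional assay on A549 cells (Homo sapiens) for cytotoxicity, read by MTT assay, with a stated time of 24 h, tested at 60 uM (on this read-out higher numbers stand for a weaker effect at the one concentration tested and lower numbers for a stronger effect), compound 1 gives 64.1%, while compound 2 gives 10.3%. For the measured compounds named here, compound 2 therefore stands at the lower of the two numbers so far, the stronger effect, and the only measured step here is a number 53.8 percentage points lower from compound 1 to compound 2 (beyond the scatter). Compound 3 `CCCCCCCCCCCCCOC(=O)CCC(=O)N1CCN(CCCOc2cc3c(Nc4ccc(F)c(Cl)c4)ncnc3cc2OC)CC1` carries the change (butyl in place of hydrogen on a saturated chain carbon, nine bonds along the chain from an oxygen next to a carbonyl group), which lengthens the same chain once more. That single step is the only one that bears on the new one, and it points downward. Compound 3 is expected to give 8%, with a range from 2% to 25%. The expected step of a number 2.3 percentage points lower from compound 2 to compound 3 (within the scatter) is small because compound 2 already gives 10.3% and leaves little room for a further fall.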

Compound 3, a percentage reported as activity, at one concentration (the size of the read-out at that concentration, not a potency): 20.6%
Beside the measured number, compound 3's estimate is 12.6 percentage points below it; the measured number falls inside the stated range.
By their numbers in this assay, from the lowest: compound 2; then compound 3; then compound 1.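

Lengthening this ester chain does not keep strengthening the effect: adding butyl nine bonds along the chain from the oxygen gives a number 10.3 percentage points higher from compound 2 to compound 3 (beyond the scatter) in this assay, so the direction seen in the first step reverses. The longer chain still keeps most of the gain, with a number 43.5 percentage points lower from compound 1 to compound 3 (beyond the scatter), which shows that the change from the shortest chain remains large even after this reversal. Nothing available explains why the added butyl weakens the effect at this position.

These three compounds cannot show whether the strongest effect lies at the chain of compound 2 or at a length on either side of it, or whether a still longer chain would weaken the effect further. Nor do they show how an amine or a carboxylic acid at the chain end would behave.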